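The source may hold more compounds than are shown below. What is called first, only, known or untested is meant among the compounds shown, and "the series" means these compounds.

Compound 1 `CC(C)=CCC/C(C)=C/CC/C(C)=C/C(=O)NC(=N)N` gives 9200 nM in a functional assay on B16-F10 cells (Mus musculus) for inhibition, read by MTT assay, with a stated time of 72 h; a lower number here means a stronger inhibitor of growth, a higher number a weaker inhibitor of growth. Compound 2 `CC(C)=CCC/C(C)=C/CC/C(C)=C/C(=O)NC(=N)NC(=O)C=C(C)C` gives 7500 nM in this assay, and the step of a 1.2-fold lower number from compound 1 to compound 2 (0.09 log units; within the scatter) stays within the scatter. Compound 3 `CC(C)=CCC/C(C)=C/C(=O)NC(=N)NC(=O)/C=C(\C)CCC=C(C)C` gives 23800 nM in this assay, the highest number of the three measured, beyond the scatter from both compound 1 and compound 2. Compound 4 `CC(C)=CCC/C(C)=C/CC/C(C)=C/C(=O)NC(=N)NC(=O)/C=C(\C)CCC=C(C)C` differs from compound 3 by 3-methylbut-2-en-1-yl in place of hydrogen on a saturated chain carbon bound to a double-bonded chain carbon. Among the compounds with values here, no measured step covers this change; the step of a 1.2-fold lower number from compound 1 to compound 2 (0.09 log units; within the scatter) concerns the amine nitrogen and not this chain. Compound 1 and compound 2, which carry the 3,7-dimethylocta-2,6-dien-1-yl chain, both show lower numbers than compound 3. A moderate lowering is therefore expected for compound 4, as the step of a 3.0-fold lower number from compound 3 to compound 4 (0.47 log units; beyond the scatter). For compound 4 the estimate in this assay is 8000 nM, within 3500 nM to 18000 nM.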

Compound 4, concentration for 50% growth inhibition: 18900 nM
For compound 4 the middle estimate is 2.4-fold (0.37 log units) below the measured one; the measured number lies above the stated range.
By their numbers in this assay, from the lowest: compounds 2 and 1 (each within the scatter of the next); then compounds 4 and 3 (each within the scatter of the next).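

In this assay, 3-methylbut-2-en-1-yl in place of hydrogen on a saturated chain carbon bound to a double-bonded chain carbon leaves the number unmoved when the partner chain is already long (a 1.3-fold lower number from compound 3 to compound 4 (0.10 log units; within the scatter)). The same change, read as 2-methylprop-1-en-1-yl to 2,6-dimethylhepta-1,5-dien-1-yl, gives a modest rise beyond the scatter (a 2.5-fold higher number from compound 2 to compound 4 (0.40 log units; beyond the scatter)). Its effect therefore depends on the starting compound.

No available evidence bears on this difference. Still open, going by these compounds, is how a terminal amine or carboxylic acid on either chain would read.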